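This account rests on a few compounds, and the source may have more. Where it says the series, first, only, none or still open, it means among the compounds named here.

Working notes on the series. The read-out is an ADME assay on microsomes from liver (Mus musculus) for metabolic stability; a lower number here means that the compound disappears faster, a higher number that the compound lasts longer. Compound 3 `Cc1cc(C(=O)Nc2ccc(Cl)cc2)ccc1N(CC(=O)N1CCOCC1)C(=O)Nc1ccc(Cl)cc1` gives 0.472 h. Compound 1 `Cc1cc(C(=O)Nc2ccc(F)cn2)ccc1N(CCN1CCCC1)C(=O)Nc1ccc(Cl)cc1` gives 0.437 h, a number within the usual scatter of that of compound 3, so the two cannot be told apart. Among the measured compounds shown here, compound 2 `Cc1cc(C(=O)Nc2ccc(Cl)cc2)ccc1N(CCN1CCCC1=O)C(=O)Nc1ccc(Cl)cc1` gives 0.147 h, and the one single-point step among the measured compounds, a 3.2-fold higher number from compound 2 to compound 3 (0.51 log units; beyond the scatter), is the only clear difference in the set so far.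

Compound 4 `Cc1cc(C(=O)Nc2ccc(Cl)cc2)ccc1N(CCN1CCCC1)C(=O)Nc1ccc(Cl)cc1` differs from compound 3 by (pyrrolidin-1-yl)methyl in place of (morpholin-4-yl)carbonyl on a saturated chain carbon bound to an amide-type nitrogen. For the measured compounds named here, no measured step covers this exact exchange. The step of a 3.2-fold higher number from compound 2 to compound 3 (0.51 log units; beyond the scatter) concerns the same place of the molecule but a different pair of groups, so it gives only a sense of scale. Compound 4 carries the same 2-(pyrrolidin-1-yl)ethyl chain as compound 1, and compound 1 gives 0.437 h, a number within the scatter of compound 3. Compound 4 is therefore expected to show a 1.1-fold lower number from compound 3 to compound 4 (0.05 log units; within the scatter), a step not beyond the usual spread. The estimate for compound 4 in this assay is 0.42 h, with a range of 0.2 h to 0.85 h.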

Compound 4, half-life: 0.597 h
Beside the measured number, compound 4's estimate is 1.4-fold (0.15 log units) below it; low and high end bracket the measured number.
By their numbers in this assay, from the lowest: compound 2; then compounds 1, 3 and 4 (each within the scatter of the next).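

In this assay, (pyrrolidin-1-yl)methyl in place of (morpholin-4-yl)carbonyl on a saturated chain carbon bound to an amide-type nitrogen gives a 1.3-fold higher number from compound 3 to compound 4 (0.10 log units; within the scatter) and so does not separate the two groups, while pyrrolidin-1-yl in place of 2-oxopyrrolidin-1-yl gives a 4.1-fold higher number from compound 2 to compound 4 (0.61 log units; beyond the scatter) as the second clear step in the set. Among the three chains at this place, only the 2-oxopyrrolidin-1-yl chain of compound 2 stands apart. Among the compounds shown here, the first reading on the other amide-type nitrogen, 4-chlorophenyl in place of 5-fluoropyridin-2-yl, gives a 1.4-fold higher number from compound 1 to compound 4 (0.14 log units; within the scatter) and separates neither group from the other.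

Nothing at hand explains the low number of compound 2. Also open, from the compounds shown here alone, is how an open-chain amine such as 2-(dimethylamino)ethyl or a carboxylic acid would read at this place.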